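This account rests on a few compounds, and the source may have more. Where it says the series, first, only, none or still open, it means among the compounds named here.

Measured compounds: compound 1 `COC(=O)[C@@H](N)CCCNC(=N)NC(=O)COc1ccc(C2=NC(C)(C)C(C)(C)N2O)cc1` and compound 2 `COC(=O)[C@@H](N)CC(=O)NCCOc1ccc(C2=[N+]([O-])C(C)(C)C(C)(C)N2O)cc1`.

In a functional assay on PC-12 cells (Rattus norvegicus) for inhibition, read by MTT assay (a lower number here means that less compound is needed, a higher number that more compound is needed for the effect), compound 1 gives 103000 nM. In this assay compound 2 gives 55600 nM, the lowest of the two numbers, though the gap to compound 1 is within the scatter. Compound 3 `CC1(C)N(O)C(c2ccc(OCCNC(=O)CC[C@H](N)C(=O)O)cc2)=[N+]([O-])C1(C)C` differs from compound 2 by 2-amino-2-carboxyethyl in place of amino(methoxycarbonyl)methyl on a saturated chain carbon bound to a carbonyl carbon. Among the compounds with values here, no measured pair shows the effect of such a change, so the expected step from compound 2 to compound 3 is set at a 1.2-fold higher number from compound 2 to compound 3 (0.07 log units; within the scatter), nothing beyond the scatter. Compound 3 is therefore expected to give about 65000 nM in this assay, between 22000 nM and 200000 nM.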

Compound 3, half-maximal effective concentration: 58100 nM
For compound 3 the middle estimate is 1.1-fold (0.05 log units) above the measured one; the range from low to high includes it.
By their numbers in this assay, from the lowest: compounds 2, 3 and 1 (each within the scatter of the next).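

In this assay, within the data shown here, 2-amino-2-carboxyethyl in place of amino(methoxycarbonyl)methyl on a saturated chain carbon bound to a carbonyl carbon gives a 1.0-fold higher number from compound 2 to compound 3 (0.02 log units; within the scatter), the first single-place step in this set. At this position, the two groups, which differ in their counts of hydrogen-bond donors and acceptors, are therefore not told apart by this assay. Nothing available bears on why this is so.

Left open is how a carboxylic acid on the shorter chain of compound 2, or a methoxycarbonyl on the longer chain of compound 3, would read, so the two parts of this exchange remain unseparated. Also open, going by these compounds, is whether a plain amine in this place would give a step beyond the scatter.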